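Bromoacetamide for propiolamide on a trimethoxyanilide scaffold

The compounds below may be only part of what the source reports. "The series", "measured", "known", "first", "only" and "open" are said of these compounds alone.

Measured so far:
compound 1 `C/C=C/C(=O)N(Cc1ccc(OC)c(C)c1)c1cc(OC)c(OC)c(OC)c1` gives 32900 nM
compound 2 `C#CC(=O)N(Cc1ccc(OC)c(O)c1)c1cc(OC)c(OC)c(OC)c1` gives 570 nM
compound 3 `COC(=O)c1cc(CNc2cc(OC)c(OC)c(OC)c2)ccc1OC` gives 41100 nM

In a functional assay on KYSE-450 cells (Homo sapiens) for inhibition, read by MTT assay, with a stated time of 48 h (a lower number here means a stronger inhibitor, a higher number a weaker inhibitor), compound 2 gives the lowest of the three numbers; compound 1 stands a long way above it, and compound 3 further still, both gaps well beyond the scatter. Compound 4 `COc1ccc(CN(C(=O)CBr)c2cc(OC)c(OC)c(OC)c2)cc1O` has not yet been measured in this assay. It differs from compound 2 in one place: bromomethyl in place of ethynyl on a carbonyl carbon. Within the data shown here, nothing in the measured pairs tracks this change, since no two measured compounds differ in exactly this way. Compound 4 is therefore expected to stay close to compound 2, with the step of a 1.6-fold higher number from compound 2 to compound 4 (0.20 log units; within the scatter) estimated to lie within or only just beyond the scatter. The estimate for compound 4 in this assay is 900 nM, with a range from 200 nM to 5000 nM.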

Compound 4, half-maximal inhibitory concentration: 120 nM
Estimate against measurement, compound 4: 7.5-fold (0.88 log units) above; measured number below the stated range.
By their numbers in this assay, from the lowest: compound 4; then compound 2; then compounds 1 and 3 (each within the scatter of the next).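

In this assay, bromomethyl in place of ethynyl on a carbonyl carbon gives a 4.8-fold lower number from compound 2 to compound 4 (0.68 log units; beyond the scatter), so at this position ethynyl can be replaced and the number still falls. This is the first step shown between compounds that differ in one place, and it puts a size on a change at this carbonyl carbon. Nothing shown explains the drop.

From the compounds shown here alone, whether chloromethyl or a plain methyl on that carbonyl carbon would give a number like that of compound 4 remains open. So does whether a number this low depends on the bromine atom itself.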